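The source may report more compounds than this note shows. Statements on the series, on what has been measured and on what is new or still open speak of the compounds shown alone.

Measured in a functional assay on HepG2 cells (Homo sapiens) for cytotoxicity, read by MTT assay, with a stated time of 48 h; a higher number here means a weaker inhibitor, a lower number a stronger inhibitor:
Compound 1 `CCCCCCCCCCCCCCCCCCNC(=O)[C@@H](N)[C@@H](C)O`: 44500 nM
Compound 2 `CCCCCCCCCCCCCCCCCCNC(=O)[C@@H](NC(=O)c1nccc2ccccc12)[C@@H](C)O`: 96900 nM
Compound 3 `CCCCCCCCCCCCCCCCCCNC(=O)[C@@H](NC(=O)/C=C/c1ccccc1)[C@@H](C)O`: 128000 nM

Compound 3 has the highest number of the three; its gap to compound 2 is within the scatter, a 1.3-fold higher number from compound 2 to compound 3 (0.12 log units; within the scatter), while its gap to compound 1 is beyond it, a 2.9-fold higher number from compound 1 to compound 3 (0.46 log units; beyond the scatter). Compound 4 `CCCCCCCCCCCCCCCCCCNC(=O)[C@@H](NS(=O)(=O)c1ccc(C)cc1)[C@@H](C)O` carries (4-methylphenyl)sulfonyl in place of (2-phenylethenyl)carbonyl on an amine nitrogen. Among the compounds with values here, no measured step trades one amine cap for another of this kind. Within the data shown here, the steps that bear on it are the two cappings of the bare amine, a 2.2-fold higher number from compound 1 to compound 2 (0.34 log units; beyond the scatter) and a 2.9-fold higher number from compound 1 to compound 3 (0.46 log units; beyond the scatter), both modest rises, and the exchange of one cap for another, a 1.3-fold higher number from compound 2 to compound 3 (0.12 log units; within the scatter), which stayed within the scatter. Compound 4 is therefore expected to move little, a 1.2-fold lower number from compound 3 to compound 4 (0.07 log units; within the scatter), and its estimate in this assay is 110000 nM, between 50000 nM and 250000 nM.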

Compound 4, half-maximal inhibitory concentration: 75800 nM
Beside the measured number, compound 4's estimate is 1.5-fold (0.16 log units) above it, and the stated range covers the measured number.
By their numbers in this assay, from the lowest: compounds 1, 4, 2 and 3 (each within the scatter of the next, the first and the last beyond it).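

Changing the link on this amine nitrogen from carbonyl to sulfonyl stays within the scatter against both the (2-phenylethenyl)carbonyl cap (a 1.7-fold lower number from compound 3 to compound 4 (0.23 log units; within the scatter)) and the (isoquinolin-1-yl)carbonyl cap (a 1.3-fold lower number from compound 2 to compound 4 (0.11 log units; within the scatter)). New here, a capped amine also stays within the scatter of the bare amine (a 1.7-fold higher number from compound 1 to compound 4 (0.23 log units; within the scatter)), so capping this nitrogen does not always give a step beyond the scatter. Nothing available explains these results.

Still open, from the compounds shown here alone, is how a small acetyl cap, or a cap carrying a carboxylic acid, would read in this assay. A shorter chain in place of the long one also remains untested among the compounds shown.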